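The source may report more compounds than this note shows. Statements on the series, on what has been measured and on what is new or still open speak of the compounds shown alone.

Measured in an ADME assay on MT4 cells (Homo sapiens) for cytotoxicity, read by MTT assay, with a stated time of 5 days; on this read-out higher numbers stand for lower toxicity in this test and lower numbers for higher toxicity in this test:
- compound 1 `N#Cc1ccc(Nc2nccc(OCC(=O)Nc3ccc(F)cc3)n2)cc1`: > 344000 nM, a limit
- compound 2 `Cc1cc(OCC(=O)Nc2ccc(C#N)cc2F)nc(Nc2ccc(C#N)cc2)n1`: > 310000 nM, a limit
- compound 3 `Cc1cnc(Nc2ccc(C#N)cc2)nc1OCC(=O)Nc1ccc(F)cc1`: > 331000 nM, a limit

None of the three has a number on this read-out. Compound 3 stands only at the limit of > 331000 nM in this assay, at which 1 of the 3 values shown sits.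

Compound 4 `Cc1cnc(Nc2ccc(C#N)cc2)nc1OCC(=O)Nc1ccccc1Cl` has 2-chlorophenyl in place of 4-fluorophenyl on an amide-type nitrogen.

One measured step comes close to this change: a step that the two limits leave unreadable from compound 1 to compound 3. It offers no size to carry over, and it is a methyl in place of hydrogen on an aromatic carbon, not a change on the amide-type nitrogen. Compound 2 is joined to the others by no single change.

With all three compounds at limits, no step beyond the scatter is expected in this assay. If any step appears, it can only be read toward lower numbers, that is, higher toxicity in this test. The expected size is an at least 1.1-fold lower number from compound 3 to compound 4 (0.04 log units; that floor lies within the scatter). For compound 4 the estimate is 300000 nM, with an expected range from 100000 nM to 340000 nM.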

Compound 4, half-maximal cytotoxic concentration: 197000 nM
The estimate for compound 4 lay 1.5-fold (0.18 log units) above the measured number, and the stated range covers the measured number.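

Of the compounds shown, compound 4 alone gives a number rather than a limit in this assay, at 197000 nM. Among these compounds, on the amide-type nitrogen, 2-chlorophenyl in place of 4-fluorophenyl therefore gives the first readable step, an at least 1.6-fold lower number from compound 3 to compound 4 (0.22 log units; that floor lies within the scatter). This size is only a floor because compound 3 has only a limit: the limit of > 331000 nM in this assay, at which 1 of the 4 values shown sits.

On these data alone, how far the true value of compound 3 lies from compound 4 remains open. So does whether the number of compound 4 follows the chlorine or its place on the ring, a question that 4-chlorophenyl and 2-fluorophenyl on the same amide-type nitrogen would separate.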